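Replacing the (4-chlorophenyl)carbamoyl group of compound 3

A few compounds are considered here, and "the series" means these few. Any claim that something is new, unique, unknown or untested is made for them only; others in the source may bear on it.

In a functional assay on a cell-free system (Platelet, plasma, Homo sapiens) for inhibition, read by turbidimetry, with a stated time of 3 min (a lower number here means a stronger inhibitor, a higher number a weaker inhibitor), compound 3 `COc1ccc(-n2nc(C(=O)Nc3ccc(Cl)cc3)cc2-c2ccc(Cl)cc2)nn1` gives 610 nM and stands at the high end of the series. Compound 2 `COc1ccc(NC(=O)c2cc(-c3ccc(Cl)cc3)n(-c3ccc(OC)nn3)n2)cc1` gives 400 nM, and a 1.5-fold higher number from compound 2 to compound 3 (0.18 log units; within the scatter) leaves the two level. Compound 1 `COc1ccc(-n2nc(C(=O)N3CCOCC3)cc2-c2ccc(Cl)cc2)nn1` gives 83 nM, and the steps away from it are a 4.8-fold higher number from compound 1 to compound 2 (0.68 log units; beyond the scatter) and a 7.3-fold higher number from compound 1 to compound 3 (0.87 log units; beyond the scatter).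

Compound 4 `COc1ccc(-n2nc(CCC(=O)N3CCCCC3)cc2-c2ccc(Cl)cc2)nn1` has 2-((piperidin-1-yl)carbonyl)ethyl in place of (4-chlorophenyl)carbamoyl on an aromatic carbon. Like compound 1, it has a non-aromatic ring on a carbonyl carbon, so the nearest guide is a 7.3-fold higher number from compound 1 to compound 3 (0.87 log units; beyond the scatter), read in reverse. Going by the values given here, no measured compound covers the added chain, so only part of that size is expected, towards a lower number, as the estimated 3.1-fold lower number from compound 3 to compound 4 (0.48 log units; beyond the scatter). For compound 4 the expected value is 200 nM, with an estimated range of 60 nM to 700 nM.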

Compound 4, half-maximal inhibitory concentration: 920 nM
Compound 4: the middle estimate sits 4.6-fold (0.66 log units) below what was measured; measured number outside the range, above it.
By their numbers in this assay, from the lowest: compound 1; then compounds 2, 3 and 4 (each within the scatter of the next, the first and the last beyond it).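

With (4-chlorophenyl)carbamoyl and 2-((piperidin-1-yl)carbonyl)ethyl on this aromatic carbon, a 1.5-fold higher number from compound 3 to compound 4 (0.18 log units; within the scatter) leaves the two level, so losing the hydrogen-bond donor and the aromatic ring of this group while gaining a non-aromatic ring does not by itself reach the number of compound 1. The larger change, an 11-fold higher number from compound 1 to compound 4 (1.04 log units; beyond the scatter), alters both the ring and the chain in one move, so the two cannot be separated. No measurement available here explains either step.

Still open, going by these compounds, is which of the two changes carries that step. (Piperidin-1-yl)carbonyl directly on the aromatic carbon and 2-((morpholin-4-yl)carbonyl)ethyl would each vary only one of them.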